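The source may hold more compounds than are shown below. What is called first, only, known or untested is meant among the compounds shown, and "the series" means these compounds.

Measured compounds:
compound 1 `COc1ccc(C2CC2C(=O)NNc2nncc3ccccc23)cc1`, 64000 nM
compound 2 `O=C(NNc1nncc2ccccc12)C1CC1c1ccc(OCC(F)(F)F)cc1`, 67000 nM
compound 3 `CCOc1ccc(C2CC2C(=O)NNc2nncc3ccccc23)cc1`, 94000 nM

All three share one core and differ only on the saturated chain carbon bound to the oxygen on the aromatic ring. In a functional assay on PC-3 cells (Homo sapiens) for inhibition, read by MTT assay, with a stated time of 72 h (a higher number here means a weaker inhibitor, a lower number a stronger inhibitor), compound 1 gives 64000 nM. Compound 2 gives 67000 nM, compound 3 gives 94000 nM. The steps among them are a 1.0-fold higher number from compound 1 to compound 2 (0.02 log units; within the scatter), a 1.5-fold higher number from compound 1 to compound 3 (0.17 log units; within the scatter) and a 1.4-fold higher number from compound 2 to compound 3 (0.15 log units; within the scatter); none of them leaves the scatter, so the three numbers are read as one level, with compound 3 at no separate standing from compound 1 or compound 2.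

Compound 4 `CC(C)=CCC/C(C)=C/COc1ccc(C2CC2C(=O)NNc2nncc3ccccc23)cc1` is not yet measured. The change from compound 3 is 2,6-dimethylhepta-1,5-dien-1-yl in place of methyl on a saturated chain carbon bound to an oxygen on an aromatic ring. The three measured steps all exchange small groups at this same place and bear on the step only in that none of them moved this assay. Nothing measured covers a chain of this length or with double bonds, so the bearing of those steps is weak. The expectation is therefore a step of a 1.2-fold lower number from compound 3 to compound 4 (0.07 log units; within the scatter), with no direction beyond the scatter supported. For compound 4 the estimate in this assay is 80000 nM, in a range from 25000 nM to 250000 nM.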

Compound 4, half-maximal inhibitory concentration: 24000 nM
Beside the measured number, compound 4's estimate is 3.3-fold (0.52 log units) above it; measured number below the stated range.
By their numbers in this assay, from the lowest: compound 4; then compounds 1, 2 and 3 (each within the scatter of the next).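

In this assay, this position is not silent: the step of a 3.9-fold lower number from compound 3 to compound 4 (0.59 log units; beyond the scatter) lies beyond the scatter, whereas exchanges among the smaller groups left the numbers at one level. The same separation appears in a 2.8-fold lower number from compound 2 to compound 4 (0.45 log units; beyond the scatter) and in a 2.7-fold lower number from compound 1 to compound 4 (0.43 log units; beyond the scatter), so compound 4 stands apart from each of the three earlier compounds, though all three steps are modest and the result does not rest on a single comparison. No evidence on hand bears on what in the 3,7-dimethylocta-2,6-dien-1-yl chain accounts for these steps.

The compounds shown leave open whether the length of the chain, its branching methyl groups or its double bonds carry the step, since all of these enter together in compound 4 and a saturated 3,7-dimethyloctyl chain or a straight octyl chain would begin to separate them. Also open, on these data alone, are whether a still longer chain would extend the step and whether a chain of similar length ending in an amine or a carboxylic acid would keep it.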